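A Methoxypyridine Swap at the Edge of the Limit

A few compounds are considered here, and "the series" means these few. Any claim that something is new, unique, unknown or untested is made for them only; others in the source may bear on it.

Compound 1 `COc1ccc(C(=O)/C=C/c2cccc(F)c2)c2c1C=CC(C)(C)O2` has no exact number in a functional assay on HepG2 cells (Homo sapiens) for antiproliferative activity, read by MTT assay, with a stated time of 24 h; a lower number here means a stronger inhibitor, a higher number a weaker inhibitor. Compound 1 reads > 10000 nM, which is a limit of the assay. Compound 3 `COc1ccc(C(=O)/C=C/c2ccc(-n3ccnc3)cc2)c2c1C=CC(C)(C)O2` reads > 10000 nM, again a limit. Most of the small set therefore rests at the limit of > 10000 nM in this assay, at which 2 of the 3 values shown sit. Only compound 2 `COc1ccc(C(=O)/C=C/c2ccc(N3CCCC3)cc2)c2c1C=CC(C)(C)O2` returns a number, 4740 nM.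

Compound 4 `COc1ccc(/C=C/C(=O)c2ccc(OC)c3c2OC(C)(C)C=C3)cn1` changes one group of compound 1: 6-methoxypyridin-3-yl in place of 3-fluorophenyl on a double-bonded chain carbon bound to a double-bonded chain carbon. Going by the values given here, the only measured step, an at least 2.1-fold higher number from compound 2 to compound 3 (0.32 log units; beyond the scatter), exchanges different groups, so it bears on this change only indirectly. It shows that one exchange can move the read-out beyond the scatter, but it gives no size for this swap. Compound 1 also offers no number to start from. Among the compounds with values here, the expectation therefore rests on compound 2 at 4740 nM, the only measured value, and no step beyond the scatter is expected in this assay. The expected change is a step that the limit leaves unreadable from compound 1 to compound 4. For compound 4 the estimated value is 11000 nM, with an expected range of 4000 nM to 30000 nM.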

Compound 4, half-maximal inhibitory concentration: > 10000 nM
Compound 4 ended at the assay's limit; the forecaster's own chance of this, stated with the estimate: 65%; the middle value does not contradict the limit.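

In this assay compound 4 gives > 10000 nM, a limit of the assay. Compound 1 also stands at a limit, so no step can be read between compound 1 and compound 4. Whether 6-methoxypyridin-3-yl and 3-fluorophenyl differ in this read-out stays open, with most of the set resting at one value: the limit of > 10000 nM in this assay, at which 3 of the 4 values shown sit.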